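Exchanging 6-methylpyridin-3-yl for 1-methyl-1H-pyrazol-5-yl in compound 3

A few compounds are considered here, and "the series" means these few. Any claim that something is new, unique, unknown or untested is made for them only; others in the source may bear on it.

In a physicochemical assay for lipophilicity (a higher number here means a more lipophilic compound, a lower number a more polar compound), compound 3 (`Cc1ccc(-c2cc(C(F)(F)F)ccc2[C@H]2CCOc3cc(S(=O)(=O)Nc4ccncn4)ccc32)cn1`) gives 3, the middle of three numbers: compound 1 (`Cn1nccc1-c1cc(C(F)(F)F)ccc1[C@H]1CCOc2cc(S(=O)(=O)Nc3ncccn3)ccc21`) stands higher at 3.7 and compound 2 (`Cn1nccc1-c1cc(C(F)(F)F)ccc1[C@H]1CCOc2cc(S(=O)(=O)Nc3cccnn3)ccc21`) lower at 2.2, both gaps beyond the scatter. Compound 4 (`Cn1nccc1-c1cc(C(F)(F)F)ccc1[C@H]1CCOc2cc(S(=O)(=O)Nc3ccncn3)ccc21`) carries 1-methyl-1H-pyrazol-5-yl in place of 6-methylpyridin-3-yl on an aromatic carbon. For the measured compounds named here, the only measured step, a number 1.50 log units lower from compound 1 to compound 2 (beyond the scatter), is large, but it changes the group on the sulfonamide nitrogen, which compound 3 and compound 4 share, so no measured step tests this exchange directly. A small downward change, not beyond the scatter, is expected for a number 0.20 log units lower from compound 3 to compound 4 (within the scatter). Compound 4 is estimated at 2.8, within an expected range of 2.3 to 3.3.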

Compound 4, distribution coefficient: 1.8
Compound 4: middle estimate off by 1.00 log units, on the high side; measured number below the stated range.
By their numbers in this assay, from the lowest: compound 4; then compound 2; then compound 3; then compound 1.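

In this assay the exchange on this aromatic carbon proves large, a number 1.20 log units lower from compound 3 to compound 4 (beyond the scatter), so this position moves the number, and not only the sulfonamide nitrogen. With 1-methyl-1H-pyrazol-5-yl held fixed, pyrimidin-4-yl on the sulfonamide nitrogen gives a large step, a number 1.90 log units lower from compound 1 to compound 4 (beyond the scatter), and a modest one, a number 0.40 log units lower from compound 2 to compound 4 (beyond the scatter), so all three nitrogen groups now stand apart. Nothing measured here gives a cause for these steps. The compounds shown leave open whether the exchange gives a similar step with pyrimidin-2-yl or pyridazin-3-yl on the sulfonamide nitrogen, and where an amine or a carboxylic acid on this aromatic carbon would stand.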